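Methoxy for fluoro on the cyclohexane-bearing series

The source may report more compounds than this note shows. Statements on the series, on what has been measured and on what is new or still open speak of the compounds shown alone.

- compound 1 `C=C(c1ccc(Cl)c(Cl)c1)C1COC(C)(C)OO1` gives 50900 nM
- compound 2 `C=C(c1ccc(F)c(F)c1)C1COC2(CCCCC2)OO1` gives 16500 nM
- compound 3 `C=C(c1ccc(Cl)c(Cl)c1Cl)C1COC2(CCCCC2)OO1` gives 1220 nM

All three values come from a functional assay on L02 cells (Homo sapiens) for inhibition, read by MTT assay, with a stated time of 72 h; a higher number here means a weaker inhibitor, a lower number a stronger inhibitor. Compound 2 at 16500 nM stands in the middle of the three. Compound 1 at 50900 nM lies higher and compound 3 at 1220 nM lies lower, both gaps beyond the usual scatter.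

Compound 4 `C=C(c1ccc(OC)c(F)c1)C1COC2(CCCCC2)OO1` differs from compound 2 by methoxy in place of fluoro on an aromatic carbon, para to a large group. For the measured compounds named here, no measured pair shows this exchange, so only a small rise in the number is expected, possibly none beyond the scatter. The estimated change is a 1.2-fold higher number from compound 2 to compound 4 (0.08 log units; within the scatter). Compound 4 is expected at 20000 nM, with an estimated range of 6000 nM to 60000 nM.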

Compound 4, half-maximal inhibitory concentration: 15400 nM
Estimate against measurement, compound 4: 1.3-fold (0.11 log units) above, and the stated range covers the measured number.
By their numbers in this assay, from the lowest: compound 3; then compounds 4 and 2 (each within the scatter of the next); then compound 1.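

In this assay, for the compounds shown here, methoxy in place of fluoro on the aromatic carbon para to a large group gives a 1.1-fold lower number from compound 2 to compound 4 (0.03 log units; within the scatter), the only comparison here of compounds differing in one place. At this position, with a fluoro group ortho, the larger methoxy, which adds a hydrogen-bond acceptor, leaves the number within the scatter of the fluoro compound. Nothing measured here bears on why this exchange leaves the number level.

On these data alone, whether an amine, a carboxylic acid or a longer chain such as ethoxy would stay as level at this position remains open. As far as these compounds go, the same exchange at the remaining fluoro group also remains open.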